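Compound 4 against the limit of the hydroxymethyl amides

This account rests on a few compounds, and the source may have more. Where it says the series, first, only, none or still open, it means among the compounds named here.

Measured in a functional assay on K562 cells (Homo sapiens) for cytotoxicity, read by MTT assay, with a stated time of 48 h; on this read-out lower numbers stand for stronger inhibition and higher numbers for weaker inhibition:
- compound 1 `COc1cc([C@@H]2C[C@]2(CO)C(=O)NCc2ccc(C)cc2)cc(OC)c1OC`: > 100000 nM (a limit)
- compound 2 `COc1cc([C@H]2C[C@]2(CO)C(=O)Nc2ccccc2Cl)cc(OC)c1OC`: > 100000 nM (a limit)
- compound 3 `CCOC(=O)[C@]1(C(=O)Nc2ccccc2Cl)C[C@@H]1c1cc(OC)c(OC)c(OC)c1`: 19500 nM

Compound 2 gives > 100000 nM in this assay, which is a limit and not a number. The series is crowded at one end, with the limit of > 100000 nM in this assay, at which 2 of the 3 values shown sit.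

Compound 4 `COc1cc([C@H]2C[C@]2(CO)C(=O)NCc2ccc(C)cc2)cc(OC)c1OC` is unmeasured. Its difference from compound 2 is 4-methylbenzyl in place of 2-chlorophenyl on an amide-type nitrogen.

Among the compounds with values here, the one measured step, an at least 5.1-fold lower number from compound 2 to compound 3 (0.70 log units; beyond the scatter), lies at another place, with the 2-chlorophenyl retained, so it does not size this change directly. Compound 1 gives > 100000 nM, also a limit, and it shares the 4-methylbenzyl and hydroxymethyl groups of compound 4, differing in stereochemistry.

No step beyond the scatter is expected, and the estimated step is a number no higher from compound 2 to compound 4 (the limit leaves the size open). Compound 4 is expected at 100000 nM, with an estimated range of 30000 nM to 300000 nM.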

Compound 4, half-maximal inhibitory concentration: > 100000 nM
Compound 4: a limit, no number (the forecaster's own chance of this, stated with the estimate: 70%); the middle value sits exactly at the limit.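

In this assay compound 4 gives > 100000 nM, a limit. No step from compound 2 or compound 1 to compound 4 can be read, as all three sit at one limit: the limit of > 100000 nM in this assay, at which 3 of the 4 values shown sit.

The compounds shown leave open whether either 4-methylbenzyl in place of 2-chlorophenyl or the configuration changes the read-out at all.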